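Sulfone analogue of the oxanyl ether in the series

This account rests on a few compounds, and the source may have more. Where it says the series, first, only, none or still open, it means among the compounds named here.

Measured compounds:
Compound 1, `Cc1cccc(C)c1-c1cccc(COc2ccc(CCC(=O)O)c(F)c2)c1`, gives 36 nM in an assay on CHO cells for displacement of a labelled ligand from Free fatty acid receptor 1 (Rattus norvegicus), read by scintillation counting, with a stated time of 90 min, in the presence of a further agent that is not named here; a higher number here means a weaker inhibitor, a lower number a stronger inhibitor.
Compound 2, `CCOCCOc1cc(C)c(-c2cccc(COc3ccc(CCC(=O)O)c(F)c3)c2)c(C)c1`, gives 4.5 nM in this assay.
Compound 3, `Cc1cc(OC2CCOCC2)cc(C)c1-c1cccc(COc2ccc(CCC(=O)O)c(F)c2)c1`, gives 6.7 nM in this assay.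

Compound 3 stands second highest of the three numbers. Its nearest neighbour is compound 2, with a 1.5-fold higher number from compound 2 to compound 3 (0.17 log units; within the scatter), a gap within the scatter; its furthest is compound 1, with a 5.4-fold lower number from compound 1 to compound 3 (0.73 log units; beyond the scatter), beyond the scatter. The two steps from the unsubstituted compound 1, an 8.0-fold lower number from compound 1 to compound 2 (0.90 log units; beyond the scatter) and a 5.4-fold lower number from compound 1 to compound 3 (0.73 log units; beyond the scatter), are both modest and in the same direction, while the two ethers on that aromatic carbon do not separate from each other.

Compound 4, `Cc1cc(OC2CCS(=O)(=O)CC2)cc(C)c1-c1cccc(COc2ccc(CCC(=O)O)c(F)c2)c1`, differs from compound 3 by 1,1-dioxothian-4-yl in place of oxan-4-yl on an oxygen on an aromatic ring. Among the measured compounds shown here, no measured step covers an oxidised sulfur in this ring; the only step that alters the group on the ring oxygen, a 1.5-fold higher number from compound 2 to compound 3 (0.17 log units; within the scatter), is within the scatter. The expectation is therefore no step beyond the scatter, a 1.2-fold higher number from compound 3 to compound 4 (0.08 log units; within the scatter) being estimated. Compound 4 is expected to give 8 nM in this assay, with a range from 3 nM to 25 nM.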

Compound 4, inhibition constant: 6.4 nM
Estimate against measurement, compound 4: 1.3-fold (0.10 log units) above; measured number inside the range.
By their numbers in this assay, from the lowest: compounds 2, 4 and 3 (each within the scatter of the next); then compound 1.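

In this assay, the position accepts 1,1-dioxothian-4-yl on the ring oxygen: a 1.0-fold lower number from compound 3 to compound 4 (0.02 log units; within the scatter) and a 1.4-fold higher number from compound 2 to compound 4 (0.15 log units; within the scatter), so the sulfone ring, with its 8 heavy atoms and 2 hydrogen-bond acceptors, does not separate from either ether. The step from the unsubstituted compound, a 5.6-fold lower number from compound 1 to compound 4 (0.75 log units; beyond the scatter), is modest and runs the same way as the two earlier ones, so all three groups on this aromatic carbon share that direction, and no compound shown goes against it. Nothing available here explains this tolerance.

Open, as far as these compounds go, is whether an amine such as piperidin-4-yl, or a carboxylic acid carried on a longer chain from the same oxygen, would stay level with these three ethers. Also open, from the compounds shown here alone, is whether the sulfone and the oxan-4-yl ether stay together in any read-out other than this one.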